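Removing the methoxy group from a sulfonamide hydroxamic acid

The compounds below may be only part of what the source reports. "The series", "measured", "known", "first", "only" and "open" are said of these compounds alone.

Compound 1 `COc1ccc(C(=O)NO)cc1NCc1ccc(OCCCCC(=O)Nc2ccc3c(c2)cc(C)c(=O)n3C)cc1`: 50%
Compound 2 `COc1ccc(C(=O)NO)cc1CS(=O)(=O)Nc1ccc2c(c1)cc(C)c(=O)n2C`: 14%
Compound 3 `COc1ccc(C(=O)NO)cc1CNc1ccc2c(c1)cc(C)c(=O)n2C`: 40%

Three hydroxamic acids sharing one bicyclic lactam fragment were examined in an assay on isolated protein for inhibition of protein deacetylase HDAC6 (Homo sapiens), read by fluorescence, with a stated time of 90 min, tested at 1 uM; a lower number here means a weaker effect, a higher number a stronger effect of the compound at the concentration tested. Compound 1 gives 50% and compound 3 gives 40%, while compound 2 gives 14%. Compound 2 thus stands lowest of the three numbers: compound 3 lies closest to it, with a number higher by more than the scatter, and compound 1 lies furthest, with a number higher by more still. No single-point comparison between any two of these measured compounds is available, so how much of that spread belongs to the linker between the two aryl parts and how much to the rest of the molecule cannot be separated here.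

Compound 4 `Cc1cc2cc(NS(=O)(=O)Cc3cccc(C(=O)NO)c3)ccc2n(C)c1=O` is the next compound to be tested. It differs from compound 2 in one place: hydrogen in place of methoxy on an aromatic carbon. In this assay, no direction for this change can be read from the measured compounds, and a step within the usual scatter seems the most reasonable expectation, as a number 1 percentage points higher from compound 2 to compound 4 (within the scatter). Compound 4 is therefore expected to give 15%, with a range from 4% to 35%.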

Compound 4, a percentage reported as inhibition, at one concentration (the size of the read-out at that concentration, not a potency): 63%
The estimate for compound 4 lay 48 percentage points below the measured number; the whole stated range lies below it.
By their numbers in this assay, from the lowest: compound 2; then compounds 3 and 1 (each within the scatter of the next); then compound 4.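

In this assay, the exchange of methoxy for hydrogen gives a number 49 percentage points higher from compound 2 to compound 4 (beyond the scatter), a large step from a change of one group. The three earlier compounds all carry the methoxy group and differ from one another in more than one place, so they could not show that this position alone, on the aromatic carbon ortho to a large group and para to the hydroxycarbamoyl group, can shift the read-out beyond the scatter. Leaving out the methoxy group is thus a change that matters in the sulfonamide series, at least for this one pair, though nothing given here bears on why the step is this large.

On these data alone, it remains open whether the step depends on hydrogen itself or only on the absence of methoxy, which a fluorine atom, a hydroxyl group or an ethoxy group at the same place would help to separate. As far as these compounds go, it is also open whether the same exchange would carry over to a compound with the amine linker of compound 3, or whether it holds only with the sulfonamide linker of compound 2 and compound 4.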